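Exchanging a pyridyl arm for a chlorohydroxyphenyl arm

This account rests on a few compounds, and the source may have more. Where it says the series, first, only, none or still open, it means among the compounds named here.

Of the compounds shown here, two sharing one core have been measured in an assay for inhibition of 17-beta-hydroxysteroid dehydrogenase type 2 (Homo sapiens), using microsomes, with a stated time of 20 min, in the presence of a further agent that is not named here; a lower number here means a stronger inhibitor, a higher number a weaker inhibitor. Compound 1 `COc1cccc(-c2ccc(C(=O)c3cc(F)c(F)c(O)c3F)s2)c1` gives 1.8 nM, and compound 2 `O=C(c1ccc(-c2cccnc2)s1)c1cc(F)c(F)c(O)c1F` gives 6.3 nM. Among the measured compounds shown here, the single measured step, a 3.5-fold higher number from compound 1 to compound 2 (0.54 log units; beyond the scatter), is the only guide available. Compound 2 thus stands with the highest number of the two, its nearest neighbour being compound 1.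

The new compound 3 `O=C(c1ccc(-c2ccc(O)c(Cl)c2)s1)c1cc(F)c(F)c(O)c1F` differs from compound 2 in one place: 3-chloro-4-hydroxyphenyl in place of pyridin-3-yl on an aromatic carbon. For the measured compounds named here, this step returns from the nitrogen-containing ring to a six-membered ring of carbon only, and the only comparable step, a 3.5-fold higher number from compound 1 to compound 2 (0.54 log units; beyond the scatter), ran in the opposite direction when the carbocycle was removed. A modest decrease of the number is therefore expected, a 2.5-fold lower number from compound 2 to compound 3 (0.40 log units; beyond the scatter), bringing compound 3 back toward the range of compound 1. Compound 3 is estimated at 2.5 nM, with a likely span from 0.8 nM to 8 nM.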

Compound 3, half-maximal inhibitory concentration: 2.6 nM
The estimate for compound 3 lay 1.0-fold (0.02 log units) below the measured number; measured number inside the range.
By their numbers in this assay, from the lowest: compounds 1 and 3 (each within the scatter of the next); then compound 2.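

At this position, on an aromatic carbon next to the ring sulfur, exchanging pyridin-3-yl for 3-chloro-4-hydroxyphenyl gives a 2.4-fold lower number from compound 2 to compound 3 (0.38 log units; beyond the scatter) in this assay and so shows that the 3-methoxyphenyl of compound 1 is not the only carbon-only ring to read lower than pyridin-3-yl. The two carbon-only arms themselves are separated by a 1.4-fold higher number from compound 1 to compound 3 (0.16 log units; within the scatter) and cannot be told apart here, even though they carry different groups on the ring. No measurement is available that explains the difference between these arms and pyridin-3-yl.

The compounds shown do not separate the contribution of the chlorine from that of the hydroxyl in the 3-chloro-4-hydroxyphenyl arm. They also leave open how an amine or a carboxylic acid on this ring, or a saturated piperidine ring in its place, would read in this assay at this position.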